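The source may report more compounds than this note shows. Statements on the series, on what has been measured and on what is new or still open speak of the compounds shown alone.

Compound 1, `O=C(Nc1nc(-c2ccccc2)nc2c1nnn2Cc1ccccc1)c1ccc(Cl)cc1`: 3550 nM
Compound 2, `O=C(Nc1nc(-c2ccccc2)nc2c1nnn2Cc1ccccc1)c1cccc([N+](=O)[O-])c1`: 4850 nM

These two values come from an assay on CHO cells for displacement of a labelled ligand from adenosine receptor A3 (Homo sapiens), read by scintillation counting; on this read-out higher numbers stand for weaker inhibition and lower numbers for stronger inhibition. Compound 2 stands with the highest of the two numbers, and its nearest neighbour is compound 1, whose value is within the scatter of it. Within the data shown here, the only measured step, a 1.4-fold higher number from compound 1 to compound 2 (0.14 log units; within the scatter), is therefore a change that the assay cannot tell apart from noise. Compound 3, `O=C(Nc1nc(-c2ccccc2)nc2c1nnn2Cc1ccccc1)c1ccccc1C(F)(F)F`, has not yet been measured. It differs from compound 2 in one place: 2-(trifluoromethyl)phenyl in place of 3-nitrophenyl on a carbonyl carbon. Among the measured compounds shown here, no measured step involves a 2-(trifluoromethyl)phenyl group, so the one step on record can only say that swapping one substituted phenyl for another on this carbonyl carbon has so far left the number unchanged. The expectation is a step of a 1.0-fold higher number from compound 2 to compound 3 (0.01 log units; within the scatter), not beyond the scatter. Compound 3 is therefore expected to give about 5000 nM in this assay, within a range from 1500 nM to 16000 nM.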

Compound 3, inhibition constant: 560 nM
Compound 3: the middle estimate sits 8.9-fold (0.95 log units) above what was measured; the whole stated range lies above it.
By their numbers in this assay, from the lowest: compound 3; then compounds 1 and 2 (each within the scatter of the next).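

Among these compounds, the substituted phenyl on this carbonyl carbon is not as indifferent as the single earlier step made it look: in this assay the change to 2-(trifluoromethyl)phenyl gives an 8.7-fold lower number from compound 2 to compound 3 (0.94 log units; beyond the scatter) and a 6.3-fold lower number from compound 1 to compound 3 (0.80 log units; beyond the scatter) which makes compound 3 the strongest inhibitor of the three. So 3-nitrophenyl and 4-chlorophenyl give numbers within the scatter of each other, while 2-(trifluoromethyl)phenyl stands clearly apart, showing that the number can move with what sits at this place. Nothing available here explains why this group gives the lower number.

These three groups differ both in the substituent and in where the name places it on the ring, so the two cannot be separated. The compounds shown leave open how 3-(trifluoromethyl)phenyl, 2-chlorophenyl or plain phenyl would compare.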